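The source may report more compounds than this note shows. Statements on the series, on what has been measured and on what is new or still open speak of the compounds shown alone.

Compound 2, `CN1C[C@H](C(=O)Nc2ccc(F)cc2F)[C@@H](c2ccc(/C=C/C(=O)Nc3ccccc3N)cc2)C1`, is examined in an in vitro ADME assay on microsomes from liver (Homo sapiens) for pharmacokinetics, read by LC-MS, with a stated time of 10 min, tested at 1 uM (on this read-out higher numbers stand for fast clearance and lower numbers for slow clearance), where compound 2 gives 12 mL/min/kg. For the measured compounds named here, its only measured neighbour is compound 1, `CN1C[C@H](C(=O)Nc2ccc(F)c(Cl)c2)[C@@H](c2ccc(/C=C/C(=O)Nc3ccccc3N)cc2)C1`, which in this assay gives 15 mL/min/kg; the two numbers sit within the scatter of each other, as the step of a 1.3-fold lower number from compound 1 to compound 2 (0.10 log units; within the scatter) shows, so neither can be said to clear faster or slower than the other.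

The unmeasured compound 3, `CN1C[C@H](C(=O)N2CCCCC2)[C@@H](c2ccc(/C=C/C(=O)Nc3ccccc3N)cc2)C1`, differs from compound 2 in one place: piperidin-1-yl in place of (2,4-difluorophenyl)amino on a carbonyl carbon. Going by the values given here, no measured step bears directly on this change. Among the compounds with values here, the one step that exists, a 1.3-fold lower number from compound 1 to compound 2 (0.10 log units; within the scatter), exchanges one substituted phenyl group on the amide-type nitrogen for another and leaves the amide hydrogen in place, whereas the change to compound 3 removes that hydrogen and replaces the aromatic ring by a non-aromatic one. Within the data shown here, the measured data therefore give no direction for this step, and the expectation for compound 3 is a step of a 1.3-fold higher number from compound 2 to compound 3 (0.10 log units; within the scatter) with a wide range to reflect that uncertainty. Compound 3 is accordingly estimated to give 15 mL/min/kg in this assay, with a range from 6 mL/min/kg to 40 mL/min/kg.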

Compound 3, clearance: 9 mL/min/kg
Beside the measured number, compound 3's estimate is 1.7-fold (0.22 log units) above it; the measured number falls inside the stated range.
By their numbers in this assay, from the lowest: compounds 3, 2 and 1 (each within the scatter of the next).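

Until now, this carbonyl carbon had only shown one substituted phenylamino group exchanged for another, with the amide hydrogen kept. Compound 3 adds a change of a different kind: piperidin-1-yl enters, the aromatic ring and the amide hydrogen both leave, and in this assay the readings still stay within the scatter, with a 1.3-fold lower number from compound 2 to compound 3 (0.12 log units; within the scatter) and a 1.7-fold lower number from compound 1 to compound 3 (0.22 log units; within the scatter) in the same read-out. Among these three compounds, then, neither an aromatic ring on the amide nitrogen nor the amide hydrogen is needed to keep the number in this narrow band, although nothing at hand offers an explanation for that.

The compounds shown leave open how far this tolerance extends, since a morpholin-4-yl ring, an open-chain dimethylamino group or a carboxylic acid on this carbonyl carbon could give a step beyond the scatter or none at all. They also leave open whether the same exchange would read alike with the rest of the shared core altered, since every compound here carries the same remainder.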